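This account rests on a few compounds, and the source may have more. Where it says the series, first, only, none or still open, it means among the compounds named here.

Measured so far:
- compound 1 `CCCCCCNc1nc(SC)nc2ncccc12`: 3330 nM
- compound 2 `CSc1nc(NC2CCC2)c2cccnc2n1`: 720 nM

Within the data shown here, in a functional assay (Nicotiana tabacum) (on this read-out lower numbers stand for stronger inhibition and higher numbers for weaker inhibition), compound 1 gives 3330 nM, the higher of the two numbers measured so far, which makes it the weaker inhibitor of the pair. Compound 3 `CSc1nc(NCc2ccccc2)c2cccnc2n1` has not yet been measured. It keeps the shared core and differs from compound 1 as follows: phenyl in place of pentyl on a saturated chain carbon bound to a nitrogen on an aromatic ring.

Among the measured compounds shown here, only one measured step bears on this change: a 4.6-fold lower number from compound 1 to compound 2 (0.67 log units; beyond the scatter). It is modest, it lies beyond the scatter, and it comes from cyclobutyl in place of hexyl on a nitrogen on an aromatic ring. Compound 3 also brings a ring where compound 1 has an open chain, so a move towards compound 2 at 720 nM is expected, though a single step is thin support and the ring here sits differently. The expected change is a lower number of similar or smaller size, estimated as a 2.6-fold lower number from compound 1 to compound 3 (0.41 log units; beyond the scatter). For compound 3 the estimated value is 1300 nM, with an expected range from 400 nM to 4000 nM.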

Compound 3, half-maximal inhibitory concentration: 25200 nM
Compound 3: the middle estimate sits 19-fold (1.29 log units) below what was measured, outside the stated range (above it).
By their numbers in this assay, from the lowest: compound 2; then compound 1; then compound 3.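

In this assay, among these compounds, the phenyl change runs in the opposite direction to the only earlier step at this position (a 7.6-fold higher number from compound 1 to compound 3 (0.88 log units; beyond the scatter)), whereas the cyclobutyl change had gone the other way (a 4.6-fold lower number from compound 1 to compound 2 (0.67 log units; beyond the scatter)). Among these three compounds, a ring in place of an open chain goes with a lower number in compound 2 and a higher number in compound 3, so the mere presence of a ring does not set the direction of the change. Nothing available here explains why the phenyl change raises the number.

The compounds shown leave open whether the higher number in compound 3 belongs to the aromatic ring itself or to the ring being carried on a saturated chain carbon, a question that a cyclohexyl group on that same chain carbon, or a phenyl group on the nitrogen itself, could help to separate. They also leave open how a shorter open chain such as butyl on the same nitrogen compares with the hexyl of compound 1.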